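Taking the Methyl Off Compound 3

The source may report more compounds than this note shows. Statements on the series, on what has been measured and on what is new or still open speak of the compounds shown alone.

Going by the values given here, in an ADME assay on Huh-7 cells (Homo sapiens) for cytotoxicity, with a stated time of 72 h (on this read-out lower numbers stand for higher toxicity in this test and higher numbers for lower toxicity in this test), three compounds built on a shared core have numbers so far. Compound 1 `COc1ccc(/C=C\c2cc(OC)c(OC)c(OC)c2)cc1NC(=O)[C@H](C)NC(=O)[C@H](CCCNC(=N)N)NC(=O)[C@H](CCCCN)NC(=O)c1ccccc1` gives 71.6 nM, compound 2 `COc1ccc(/C=C\c2cc(OC)c(OC)c(OC)c2)cc1NC(=O)[C@H](CO)NC(=O)[C@H](CCCNC(=N)N)NC(=O)[C@H](CCCNC(=N)N)NC(=O)c1ccccc1` gives 23.1 nM, and compound 3 `COc1ccc(/C=C\c2cc(OC)c(OC)c(OC)c2)cc1NC(=O)[C@H](C)NC(=O)[C@H](CCCNC(=N)N)NC(=O)[C@H](CCCNC(=N)N)NC(=O)c1ccccc1` gives 191 nM. Compound 3 thus holds the highest of the three numbers, and both of its gaps lie beyond the usual scatter.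

Compound 4 `COc1ccc(/C=C\c2cc(OC)c(OC)c(OC)c2)cc1NC(=O)CNC(=O)[C@H](CCCNC(=N)N)NC(=O)[C@H](CCCNC(=N)N)NC(=O)c1ccccc1` differs from compound 3 in one place: hydrogen in place of methyl on a saturated chain carbon bound to an amide-type nitrogen and a carbonyl carbon. This puts hydrogen in place of methyl on a saturated chain carbon bound to an amide-type nitrogen and a carbonyl carbon.

The more relevant measured step is an 8.3-fold higher number from compound 2 to compound 3 (0.92 log units; beyond the scatter). It concerns the same methyl carbon that compound 4 gives up, and it shows that a change there can move the number clearly. The other step, a 2.7-fold higher number from compound 1 to compound 3 (0.43 log units; beyond the scatter), lies on a different chain and says less. Among the compounds with values here, no measured step removes this methyl, so its size remains uncertain. With compound 3 at the top of the series, a modest move downward seems most likely, smaller than the step seen with compound 2.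

The expected change is a 2.2-fold lower number from compound 3 to compound 4 (0.35 log units; beyond the scatter). Compound 4 is estimated at 85 nM, with an expected range of 30 nM to 250 nM.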

Compound 4, half-maximal cytotoxic concentration: 26.6 nM
Beside the measured number, compound 4's estimate is 3.2-fold (0.50 log units) above it; measured number below the stated range.
By their numbers in this assay, from the lowest: compounds 2 and 4 (each within the scatter of the next); then compound 1; then compound 3.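

In this assay, going by these compounds alone, the step of a 7.2-fold lower number from compound 3 to compound 4 (0.86 log units; beyond the scatter) shows for the first time that the methyl itself matters on this saturated chain carbon, since the earlier compounds only showed hydroxymethyl compared with methyl there. The step of a 1.2-fold higher number from compound 2 to compound 4 (0.06 log units; within the scatter) then sets hydrogen and hydroxymethyl level, so among compounds 2, 3 and 4, which share the rest of their structure, only the methyl of compound 3 goes with the high number, and adding or removing a single hydroxy or methyl does not move the number in one steady direction along this series. No measurement at hand says why methyl stands apart from the other two groups here.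

The compounds shown leave open whether a longer chain such as ethyl or isopropyl, or an amine or a carboxylic acid on this carbon, would stay with compound 3 or fall in with compound 2 and compound 4. They also leave open whether hydrogen in place of methyl would move the number as far in compound 1, which carries the aminobutyl chain of lysine elsewhere.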